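This account rests on a few compounds, and the source may have more. Where it says the series, first, only, none or still open, it means among the compounds named here.

Compound 1 `COc1cc(-c2nnc3n2NC(c2ccco2)C(C(=O)c2ccc(C)cc2)S3)cc(OC)c1OC` and compound 2 `COc1cc(-c2nnc3n2NC(c2ccco2)C(C(=O)c2ccc(C(F)(F)F)cc2)S3)cc(OC)c1OC` share the same core and differ only in the group on the six-membered aromatic ring of carbon only. In a functional assay on A549 cells (Homo sapiens) for cytotoxicity, read by MTT assay, with a stated time of 48 h (on this read-out lower numbers stand for stronger inhibition and higher numbers for weaker inhibition), compound 1 gives only a limit, > 100000 nM. Among the measured compounds shown here, compound 2 gives 37200 nM, the only plain number among the values shown. The step of an at least 2.6-fold lower number from compound 1 to compound 2 (0.42 log units; beyond the scatter) rests on that limit (the limit of > 100000 nM in this assay, at which 1 of the 2 values shown sits). Compound 3 `COc1cc(-c2nnc3n2NC(c2ccco2)C(C(=O)c2ccc([N+](=O)[O-])cc2)S3)cc(OC)c1OC` carries nitro in place of trifluoromethyl on an aromatic carbon. For the measured compounds named here, only that one measured step bears on this change, and it was at least modest, so the expected step of a 1.2-fold lower number from compound 2 to compound 3 (0.09 log units; within the scatter) is small. The estimate for compound 3 in this assay is 30000 nM, within 10000 nM to 100000 nM.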

Compound 3, half-maximal inhibitory concentration: > 100000 nM
Compound 3: a limit, no number; the forecaster's own chance of this, stated with the estimate: 25%; middle value at least 3.3-fold (0.52 log units) away from the limit.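

In this assay, the change at this position gives an at least 2.6-fold higher number from compound 2 to compound 3 (0.42 log units; beyond the scatter). Among the compounds shown, trifluoromethyl is therefore the only group on this ring with a plain number, and nitro joins methyl at the limit of the assay. The step from compound 1 to compound 3 cannot be read, and the new step also rests on a limit: the limit of > 100000 nM in this assay, at which 2 of the 3 values shown sit.

On these data alone, whether a chlorine atom or an amine at this position would give a plain number remains open. So does how far below the number of compound 2 any group could go.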